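Chloro to isopropyl on the fluorinated aryl ring

A few compounds are considered here, and "the series" means these few. Any claim that something is new, unique, unknown or untested is made for them only; others in the source may bear on it.

The shared core carries a fluorinated aryl ring whose further substituent varies. In an assay on cells for inhibition of Palmitoleoyl-protein carboxylesterase NOTUM variant C330S (Homo sapiens), read by fluorescence, with a stated time of 40 min (on this read-out lower numbers stand for stronger inhibition and higher numbers for weaker inhibition), compound 1 `Cc1cc(C(=O)O)c(C)n1-c1cccc(C#N)c1F` gives 630 nM, compound 2 `Cc1cc(C(=O)O)c(C)n1-c1ccccc1F` gives 3300 nM, and compound 3 `Cc1cc(C(=O)O)c(C)n1-c1cccc(Cl)c1F` gives 380 nM. Compound 3 holds the lowest of the three numbers; its nearest neighbour is compound 1, within the scatter, and its furthest is compound 2, beyond the scatter. Among the single-site steps, an 8.7-fold lower number from compound 2 to compound 3 (0.94 log units; beyond the scatter) and a 5.2-fold higher number from compound 1 to compound 2 (0.72 log units; beyond the scatter) are both modest but clear, whereas a 1.7-fold lower number from compound 1 to compound 3 (0.22 log units; within the scatter) stays within the scatter.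

Compound 4 `Cc1cc(C(=O)O)c(C)n1-c1cccc(C(C)C)c1F` differs from compound 3 by isopropyl in place of chloro on an aromatic carbon. Going by the values given here, no measured step involves isopropyl at this position. Among the compounds with values here, the steps that bear on it show that removing the group costs potency, seen in an 8.7-fold lower number from compound 2 to compound 3 (0.94 log units; beyond the scatter), while exchanging chloro for cyano does not register, seen in a 1.7-fold lower number from compound 1 to compound 3 (0.22 log units; within the scatter). Isopropyl is a larger group than either, and the data give no guide on size. The expectation for this assay is therefore a step within or only slightly beyond the scatter, in either direction, centred near the present number. The estimate for compound 4 in this assay is 500 nM, with a range from 150 nM to 1700 nM. The estimated step from compound 3 to compound 4 is a 1.3-fold higher number from compound 3 to compound 4 (0.12 log units; within the scatter).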

Compound 4, half-maximal inhibitory concentration: 150 nM
Compound 4: the middle estimate sits 3.3-fold (0.52 log units) above what was measured, within the range that was stated.
By their numbers in this assay, from the lowest: compound 4; then compounds 3 and 1 (each within the scatter of the next); then compound 2.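

In this assay, isopropyl on this aromatic carbon, ortho to a fluoro group, gives a 2.5-fold lower number from compound 3 to compound 4 (0.40 log units; beyond the scatter) and so separates itself from chloro, which the earlier swap of chloro for cyano at the same place did not do for those two groups. Going by these compounds alone, the position therefore does more than reward any substituent over hydrogen: the step to isopropyl is a 22-fold lower number from compound 2 to compound 4 (1.34 log units; beyond the scatter) and is the only large step in the set, while the exchange for cyano gives a 4.2-fold lower number from compound 1 to compound 4 (0.62 log units; beyond the scatter) and leaves compound 4 with the lowest number of the four, beyond the scatter of each of the others. Nothing available accounts for this order among hydrogen, cyano, chloro and isopropyl.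

Open, on these data alone, is whether the trend continues with other carbon groups at this place, such as ethyl, cyclopropyl or tert-butyl, or where it stops as the branching grows. Also open, as far as these compounds go, is how a trifluoromethyl, a methoxy or an amine would rank here against isopropyl and chloro, since the four compounds include none of these groups.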